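This account rests on a few compounds, and the source may have more. Where it says the series, first, only, none or still open, it means among the compounds named here.

Of the compounds shown here, two have numbers so far in a functional assay on ileum (strain Hartley) for agonist activity at 5-hydroxytryptamine receptor 3A (Cavia porcellus); on this read-out lower numbers stand for lower potency and higher numbers for higher potency (the scale is a negative logarithm). Compound 1 `COc1ccc2oc(N3CCN(C)CC3)nc2c1` gives 4.78 there, and compound 2 `CCc1cccc2nc(N3CCN(C)CC3)oc12` gives 5.48, so compound 1 holds the lower of the two numbers, with compound 2 a step beyond the usual scatter above it. Compound 3 `CN1CCN(c2nc3cc(Br)ccc3o2)CC1` has not yet been measured. It differs from compound 1 in one place: bromo in place of methoxy on an aromatic carbon. The methoxy leaves and bromo enters, meta to a fused ring and para to a fused ring. Among the compounds with values here, no measured pair shows such a change, so the step is an expectation only: a rise beyond the scatter, a number 0.82 log units higher from compound 1 to compound 3 (beyond the scatter), is expected in this assay. Compound 3 is accordingly estimated at 5.6, between 5 and 6.3.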

Compound 3, negative logarithm of the half-maximal effective concentration: 6.21
Beside the measured number, compound 3's estimate is 0.61 log units below it; low and high end bracket the measured number.
By their numbers in this assay, from the lowest: compound 1; then compound 2; then compound 3.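

In this assay, within the data shown here, bromo in place of methoxy on this aromatic carbon, meta to a fused ring and para to a fused ring, gives a number 1.43 log units higher from compound 1 to compound 3 (beyond the scatter), the first measured step at this position. The position is therefore not indifferent to its group, since this one change separates the two compounds by a large step. Nothing available accounts for the size of that step.

On these data alone, whether chloro, methyl or an amine on this carbon would go as far as bromo stays open. So does whether the same change elsewhere on the shared core would give a step of similar size.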